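The source may hold more compounds than are shown below. What is called first, only, known or untested is meant among the compounds shown, and "the series" means these compounds.

In a functional assay on SK-MEL-28 cells (Homo sapiens) for cytotoxicity, read by MTT assay, with a stated time of 3 days (a lower number here means a stronger inhibitor, a higher number a weaker inhibitor), compound 1 `N#Cc1c(Cl)nc(SCc2nc3ccccc3[nH]2)nc1-c1ccccc1` gives 3.28 nM while compound 2 `CNc1nc(SCc2nc3ccccc3[nH]2)nc(-c2ccccc2)c1C#N` gives 2.87 nM and compound 3 `N#Cc1c(NC(N)=S)nc(SCc2nc3ccccc3[nH]2)nc1-c1ccccc1` gives 4.8 nM as its value. Compound 3 therefore sits within the scatter of both other compounds. The next compound is compound 4 `N#Cc1c(NC(N)=O)nc(SCc2nc3ccccc3[nH]2)nc1-c1ccccc1` and the change leading to it is a group of 3 heavy atoms (1 carbon, 1 nitrogen, 1 oxygen; no ring) in place of a group of 3 heavy atoms (1 carbon, 1 nitrogen, 1 sulfur; no ring), on a nitrogen on an aromatic ring with carbamoyl entering on a nitrogen on an aromatic ring. Among the compounds with values here, no measured step makes this same exchange, so the evidence is only indirect. The measured steps that bear on it all concern the same substituent. They are a 1.1-fold lower number from compound 1 to compound 2 (0.06 log units; within the scatter) and a 1.5-fold higher number from compound 1 to compound 3 (0.17 log units; within the scatter) and a 1.7-fold higher number from compound 2 to compound 3 (0.22 log units; within the scatter) and none of them leaves the scatter. A step beyond the scatter is therefore not expected in this assay in either direction. The estimated step is a 1.2-fold lower number from compound 3 to compound 4 (0.08 log units; within the scatter) and it is expected to stay small. Compound 4 is expected at 4 nM within an estimated range of 1.5 nM to 12 nM in this test.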

Compound 4, half-maximal inhibitory concentration: 4.8 nM
Beside the measured number, compound 4's estimate is 1.2-fold (0.08 log units) below it; the measured number falls inside the stated range.
By their numbers in this assay, from the lowest: compounds 2, 1, 3 and 4 (each within the scatter of the next).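

Within the data shown here, with carbamoyl on the nitrogen on an aromatic ring in place of the sulfur-bearing group of the same heavy-atom count, this assay shows no change at the digits printed from compound 3 to compound 4 (within the scatter), so the exchange of sulfur for oxygen, which no earlier step covered, leaves the read-out unmoved. Carbamoyl in place of methyl on that nitrogen also stays within the scatter (a 1.7-fold higher number from compound 2 to compound 4 (0.22 log units; within the scatter)), as does ureido in place of chloro on the aromatic carbon (a 1.5-fold higher number from compound 1 to compound 4 (0.17 log units; within the scatter)). All four compounds shown therefore lie within the scatter of one another, and none goes against this flat picture at the position.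

The compounds shown leave open whether a carboxylic acid, a longer alkyl chain or a morpholine ring at this place would move the number beyond the scatter. Nothing shown offers an explanation for the flat picture.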